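Chloro-methylpyridyl ether: expected solubility of compound 4

A few compounds are considered here, and "the series" means these few. Any claim that something is new, unique, unknown or untested is made for them only; others in the source may bear on it.

Measured compounds:
compound 1, `Cc1cccc(Oc2ccc3nc(COc4cccc(C(=O)O)c4)n(C)c3c2)n1`, 92 ug/mL
compound 2, `Cn1c(COc2cccc(C(=O)O)c2)nc2ccc(Oc3ccc(F)cn3)cc21`, 79 ug/mL
compound 3, `Cc1ccc(C)c(Oc2ccc3nc(COc4cccc(C(=O)O)c4)n(C)c3c2)n1`, 85 ug/mL

In a physicochemical assay for solubility, read by HPLC, measured as thermodynamic solubility, with a stated time of 4 h, at pH 6.8 (on this read-out higher numbers stand for higher solubility and lower numbers for lower solubility), the three compounds differ only in the pyridyl group on the aryl ether oxygen. Compound 3 stands level with the other two: the step of a 1.1-fold lower number from compound 1 to compound 3 (0.03 log units; within the scatter) and the step of a 1.1-fold higher number from compound 2 to compound 3 (0.03 log units; within the scatter) both lie within the scatter, as does the step of a 1.2-fold lower number from compound 1 to compound 2 (0.07 log units; within the scatter). Compound 4, `Cc1cc(Cl)cnc1Oc1ccc2nc(COc3cccc(C(=O)O)c3)n(C)c2c1`, carries the change (5-chloro-3-methylpyridin-2-yl in place of 3,6-dimethylpyridin-2-yl on an oxygen on an aromatic ring). Going by the values given here, the measured steps that bear on it are those exchanging one pyridyl substituent pattern for another on this same oxygen, and none of them moved this assay beyond the scatter; the closest precedent is the exchange of a methyl for a halogen from compound 1 to compound 2, which was small. On that basis compound 4 is expected to show a step of a 1.2-fold lower number from compound 3 to compound 4 (0.08 log units; within the scatter), that is, no shift beyond the scatter. The solubility of compound 4 is therefore estimated at 70 ug/mL, with a range from 35 ug/mL to 140 ug/mL.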

Compound 4, solubility: 3.9 ug/mL
Beside the measured number, compound 4's estimate is 18-fold (1.25 log units) above it, and the stated range ends above it.
By their numbers in this assay, from the lowest: compound 4; then compounds 2, 3 and 1 (each within the scatter of the next).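

In this assay, going by these compounds alone, the position on an oxygen on an aromatic ring proves far less forgiving than the earlier compounds suggested: the 5-chloro-3-methylpyridin-2-yl group brings a 22-fold lower number from compound 3 to compound 4 (1.34 log units; beyond the scatter) and stands just as far from the other two groups, with a 20-fold lower number from compound 2 to compound 4 (1.31 log units; beyond the scatter) and a 24-fold lower number from compound 1 to compound 4 (1.37 log units; beyond the scatter) on the same read-out. Three pyridyl groups had stood within the scatter of one another, so exchanging substituents on this ring can matter greatly, even with the heavy-atom count, hydrogen-bond donors, hydrogen-bond acceptors and net charge the same as in 3,6-dimethylpyridin-2-yl. Nothing available here explains the fall.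

Compound 4 is the only compound with chlorine, and the compounds shown leave open whether the fall follows the chlorine itself or its pairing with the methyl. Nor do they show how a pyridyl group would read with a methoxy group or an amine in place of that chlorine.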